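The compounds below may be only part of what the source reports. "The series", "measured", "known", "first", "only" and "open" are said of these compounds alone.

Compound 1, `O=C(/C=C\Nc1ccc(F)cc1)c1nc(-c2ccc(F)cc2)n2ccccc12`, in a functional assay on B16-F10 cells (Mus musculus) for cytotoxicity, read by MTT assay, with a stated time of 48 h; on this read-out higher numbers stand for weaker inhibition and lower numbers for stronger inhibition: > 30000 nM, a limit of the assay rather than a number.
Compound 2, `O=C(/C=C\Nc1ccc2[nH]ccc2c1)c1nc(-c2ccc(C(F)(F)F)cc2)n2ccccc12`, in this assay: 18200 nM.

For the measured compounds named here, compound 2 is the only compound with an actual number here; the one other value shown is a limit. Compound 1 sits at the limit of > 30000 nM in this assay, at which 1 of the 2 values shown sits, so only an edge is known for it. Compound 3, `O=C(/C=C\Nc1ccc(F)cc1)c1nc(-c2ccc(C(F)(F)F)cc2)n2ccccc12`, has not been measured. It differs from compound 2 in one place: 4-fluorophenyl in place of 1H-indol-5-yl on an amine nitrogen. Going by the values given here, since no two measured compounds differ in just one place, no step has been measured, and the expectation has to rest on the pattern among the three structures. Compound 3 shares its amine-side group with compound 1 and its other aryl group with compound 2, which makes it plausible that compound 3 lands somewhere between them, probably toward the weaker side. The step from compound 2 to compound 3 is therefore expected to be a 1.6-fold higher number from compound 2 to compound 3 (0.22 log units; within the scatter), toward weaker inhibition, though not clearly beyond the scatter. Compound 3 is expected to give about 30000 nM, within a range from 14000 nM to 65000 nM, with a real chance that only a limit is reported.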

Compound 3, half-maximal inhibitory concentration: > 30000 nM
Compound 3: a limit, no number; the forecaster's own chance of this, stated with the estimate: 50%; the middle value lies on the limit itself.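

In this assay, for the compounds shown here, this is the first pair that differs in one place, and with the trifluoromethyl side held fixed, 4-fluorophenyl in place of 1H-indol-5-yl on the amine nitrogen gives an at least 1.6-fold higher number from compound 2 to compound 3 (0.21 log units; that floor lies within the scatter). Compound 3 gives > 30000 nM, which is a limit of the assay and not a number, so the printed step is only a floor and the true difference could be larger or could stay within the usual scatter. Only compound 2, with 1H-indol-5-yl, has a number so far, and both compounds with 4-fluorophenyl on the amine nitrogen stop at the limit: the limit of > 30000 nM in this assay, at which 2 of the 3 values shown sit.

On these data alone, the step from compound 1 to compound 3 cannot be read, so what trifluoromethyl in place of fluoro on an aromatic carbon does at this position stays open. Also open, as far as these compounds go, is whether the number for compound 2 depends on the 1H-indol-5-yl group as a whole, which a plain phenyl or a phenyl carrying a hydroxyl or an amine on the amine nitrogen could help to separate.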